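The compounds below may be only part of what the source reports. "The series", "measured", "known", "first", "only" and "open" are said of these compounds alone.

In a functional assay on PC-3 cells (Homo sapiens) for cytotoxicity, read by MTT assay, with a stated time of 72 h (on this read-out lower numbers stand for stronger inhibition and higher numbers for weaker inhibition), compound 1 `Cn1ccc2c(Oc3ccc(NC(=O)c4nn(-c5ccc(Br)cc5F)ccc4=O)cc3F)ccnc21` gives 16300 nM. Compound 2 `Cc1cc(=O)n(-c2ccc(F)cc2)nc1C(=O)Nc1ccc(Oc2ncnc3[nH]ccc23)cc1` was tested in this assay as well. For compound 2 this assay reports only a limit, > 60000 nM, and not a number. That value sits at the limit of > 60000 nM in this assay, at which 1 of the 2 values shown sits. Compound 3 `Cc1ccc(-n2nc(C(=O)Nc3ccc(Oc4ncnc5[nH]ccc45)cc3)c(C)cc2=O)cc1` has not yet been measured in this assay. It differs from compound 2 by methyl in place of fluoro on an aromatic carbon. Going by the values given here, no pair of measured compounds here shows this exact change, so no measured step tells how large its effect is. With only the limit of compound 2 to go on, the step expected here, a number no higher from compound 2 to compound 3 (the limit leaves the size open), is none beyond the usual scatter. Compound 3 is therefore estimated at 60000 nM, with a range from 20000 nM to 200000 nM, and this assay may well again report only a limit for it.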

Compound 3, half-maximal inhibitory concentration: 9610 nM
For compound 3 the middle estimate is 6.2-fold (0.80 log units) above the measured one; the measured number lies below the stated range.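

For compound 2 the value > 60000 nM in this assay is a limit of the assay and not a number. Methyl in place of fluoro on this aromatic carbon, turning 4-fluorophenyl into 4-methylphenyl, gives an at least 6.2-fold lower number from compound 2 to compound 3 (0.79 log units; beyond the scatter) and so shows that the group at this spot can shift the read-out by more than the usual scatter. The earlier compounds shown here could not show this, since compound 1 and compound 2 differ in more than one place and no single change could be read between them.

The compounds shown leave open how a chloro group, a methoxy group or an amine at this same spot would read. The full size of the step also stays open, because one end of it is only a limit: the limit of > 60000 nM in this assay, at which 1 of the 3 values shown sits.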